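The source may hold more compounds than are shown below. What is called first, only, known or untested is meant among the compounds shown, and "the series" means these compounds.

Within the data shown here, compound 1 `Cc1ccc2[nH]c3c4cn[nH]c4c4c(c3c2c1)C(=O)NC4=O` is the one compound here with a number in a functional assay on B16-F10 cells (Mus musculus) for cytotoxicity, read by MTT assay, with a stated time of 72 h (on this read-out higher numbers stand for weaker inhibition and lower numbers for stronger inhibition), where compound 1 gives 2000 nM. Compound 2 `COc1ccc2[nH]c(-n3cccn3)cc2c1` reaches a limit of the assay rather than a number, > 100000 nM, so that the limit of > 100000 nM in this assay, at which 1 of the 2 values shown sits, holds one of the two values shown. Compound 3 `O=C1NC(=O)c2c1c1[nH]ncc1c1[nH]c3ccccc3c21` differs from compound 1 in one place: hydrogen in place of methyl on an aromatic carbon. Among the measured compounds shown here, no measured pair shows what this change does in this assay, so no step beyond the usual scatter is expected, in either direction. Compound 3 is expected to give about 3000 nM, within a range from 1000 nM to 9000 nM, an estimated step of a 1.5-fold higher number from compound 1 to compound 3 (0.18 log units; within the scatter).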

Compound 3, half-maximal inhibitory concentration: 75000 nM
Beside the measured number, compound 3's estimate is 25-fold (1.40 log units) below it; the measured number lies above the stated range.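

In this assay, among these compounds, the methyl on the aromatic carbon of compound 1 proves to matter: hydrogen in its place gives a 38-fold higher number from compound 1 to compound 3 (1.57 log units; beyond the scatter), the first step that can be read here. A change of one heavy atom at this place is therefore enough to weaken inhibition well beyond the scatter. Nothing shown gives a reason for this step. The compounds shown leave open whether ethyl, methoxy or an amine at this carbon would keep the number of compound 1, lower it or raise it.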